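Pyridine replacements on the shared core: solubility notes

A few compounds are considered here, and "the series" means these few. Any claim that something is new, unique, unknown or untested is made for them only; others in the source may bear on it.

compound 1 `COc1cc(-c2noc([C@H](C)NC(=O)c3cc(C(F)(F)F)nn3C)n2)cc(C)n1` gives 3000 nM
compound 2 `C[C@H](NC(=O)c1cc(C(F)(F)F)nn1C)c1nc(-c2ccnc(C3CC3)c2)no1` gives 16000 nM
compound 3 `COCc1cc(-c2noc([C@H](C)NC(=O)c3cc(C(F)(F)F)nn3C)n2)ccn1` gives 200000 nM

In a physicochemical assay for solubility, measured as kinetic solubility (on this read-out lower numbers stand for lower solubility and higher numbers for higher solubility), compound 1 stands lowest of the three. Compound 4 `CNc1cc(-c2noc([C@H](C)NC(=O)c3cc(C(F)(F)F)nn3C)n2)ccn1` has 2-(methylamino)pyridin-4-yl in place of 2-methoxy-6-methylpyridin-4-yl on an aromatic carbon and has not yet been measured. Two measured steps replace the same group: the modest 5.3-fold higher number from compound 1 to compound 2 (0.73 log units; beyond the scatter) and the large 67-fold higher number from compound 1 to compound 3 (1.82 log units; beyond the scatter) both go upward. The replacements themselves differ widely, as a 13-fold higher number from compound 2 to compound 3 (1.10 log units; beyond the scatter) shows, and neither carries a methylamino group, so the size remains uncertain. The step expected in this assay is upward, between those two in size, estimated as a 10-fold higher number from compound 1 to compound 4 (1.00 log units; beyond the scatter) for now. For compound 4 the expected value is 30000 nM with a range from 7000 nM to 120000 nM as the estimate.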

Compound 4, solubility: 143000 nM
The estimate for compound 4 lay 4.8-fold (0.68 log units) below the measured number, outside the stated range (above it).
By their numbers in this assay, from the lowest: compound 1; then compound 2; then compounds 4 and 3 (each within the scatter of the next).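

In (this assay) the change to 2-(methylamino)pyridin-4-yl on this aromatic carbon gives a large rise (a 48-fold higher number from compound 1 to compound 4 (1.68 log units; beyond the scatter)). Methylamino and methoxymethyl cannot be told apart at this place (a 1.4-fold lower number from compound 3 to compound 4 (0.15 log units; within the scatter)), so a second, different replacement reaches the level of compound 3. Cyclopropyl remains clearly apart from methylamino (an 8.9-fold higher number from compound 2 to compound 4 (0.95 log units; beyond the scatter)), so replacing 2-methoxy-6-methylpyridin-4-yl does not by itself set the level.

No measurement available here explains these differences. On these data alone, whether a dimethylamino group or a longer ether chain would hold this level remains open.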